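Swapping 4-fluorophenyl for 2,4-dihydroxyphenyl on a carbonyl carbon

A few compounds are considered here, and "the series" means these few. Any claim that something is new, unique, unknown or untested is made for them only; others in the source may bear on it.

Measured so far in a functional assay on A231 cells (Homo sapiens) for antiproliferative activity, read by MTT assay, with a stated time of 48 h; on this read-out lower numbers stand for stronger inhibition and higher numbers for weaker inhibition

Compound 1 `COc1ccc(OC)c(CN2CCc3nc(N4CCN(c5ncccn5)CC4)ncc3C2)c1` gives 27500 nM
Compound 2 `COc1ccc(OC)c(C(=O)N2CCc3nc(N4CCN(c5ncccn5)CC4)ncc3C2)c1` gives 51300 nM
Compound 3 `O=C(c1ccc(F)cc1)N1CCc2nc(N3CCN(c4ncccn4)CC3)ncc2C1` gives 54400 nM

Compound 3 cannot be told apart from the other two compounds on these numbers, since both of its measured steps stay within the usual scatter. The next compound, compound 4 `O=C(c1ccc(O)cc1O)N1CCc2nc(N3CCN(c4ncccn4)CC3)ncc2C1`, keeps the shared core and places 2,4-dihydroxyphenyl in place of 4-fluorophenyl on a carbonyl carbon.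

Among the measured compounds shown here, the closest precedent is a swap at the same carbonyl carbon, 4-fluorophenyl in place of 2,5-dimethoxyphenyl (a 1.1-fold higher number from compound 2 to compound 3 (0.03 log units; within the scatter)). A larger exchange, (4-fluorophenyl)carbonyl in place of 2,5-dimethoxybenzyl on an amine nitrogen in a ring, was also small (a 2.0-fold higher number from compound 1 to compound 3 (0.30 log units; within the scatter)). Neither step moved the number beyond the scatter, so no clear shift in either direction is expected in this assay here. For the measured compounds named here, no measured compound carries the 2,4-dihydroxyphenyl group, so the range is kept wide. The expected change is a 1.8-fold lower number from compound 3 to compound 4 (0.26 log units; within the scatter) and no more than that. Compound 4 is estimated at 30000 nM with an expected range from 8000 nM to 75000 nM in this test.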

Compound 4, half-maximal inhibitory concentration: 21300 nM
Compound 4: the middle estimate sits 1.4-fold (0.15 log units) above what was measured, and the stated range covers the measured number.
By their numbers in this assay, from the lowest: compounds 4, 1, 2 and 3 (each within the scatter of the next, the first and the last beyond it).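

In this assay, the group on this carbonyl carbon can now move the number beyond the scatter: 2,4-dihydroxyphenyl in place of 4-fluorophenyl gives a 2.6-fold lower number from compound 3 to compound 4 (0.41 log units; beyond the scatter), and in place of 2,5-dimethoxyphenyl it gives a 2.4-fold lower number from compound 2 to compound 4 (0.38 log units; beyond the scatter), while the earlier swap at this carbon stayed within the scatter. The effect does not separate this amide from the amine-linked 2,5-dimethoxybenzyl compound, with a 1.3-fold lower number from compound 1 to compound 4 (0.11 log units; within the scatter). Nothing measured here accounts for the shift.

As far as these compounds go, whether a phenyl ring carrying a single hydroxyl, an amine or a carboxylic acid would do the same at this carbonyl carbon stays open. So does the effect of a 2,4-dihydroxybenzyl group on the amine nitrogen in a ring, which would combine the features of the two compounds in that last step.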